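The source may report more compounds than this note shows. Statements on the series, on what has been measured and on what is new or still open speak of the compounds shown alone.

For the measured compounds named here, compound 2 `Cc1ccc(N2CCn3c2n[nH]c(=O)c3=N)cc1` is one of three compounds measured in a functional assay on A549 cells (Homo sapiens) for antiproliferative activity, with a stated time of 72 h, tested at 10 ug/mL (on this read-out higher numbers stand for a stronger effect at the one concentration tested and lower numbers for a weaker effect), where compound 2 gives 37%. Among the three numbers it is the top one, yet compound 1 `N=c1c(=O)[nH]nc2n1CCN2c1cccc(Cl)c1`, which in this assay gives 36%, lies within the usual scatter of it, so the two cannot be told apart. Compound 3 `COc1ccccc1N1CCn2c1n[nH]c(=O)c2=O`, which in this assay gives 0%, lies well beyond the scatter from both.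

The next compound, compound 4 `N=c1c(=O)[nH]nc2n1CCN2c1ccc(Cl)cc1`, is not yet measured. Compared with compound 2 it differs by chloro in place of methyl on an aromatic carbon. The change is small: one heavy atom replaces one heavy atom, with no change in ring count, hydrogen-bond donors or acceptors, or charge. Going by the values given here, no step between measured compounds isolates this exchange, but compound 1 also carries a chloro group on its ring and, with 36%, sits within the scatter of compound 2, which offers the nearest guide. The expected step is therefore a number 2 percentage points lower from compound 2 to compound 4 (within the scatter), none beyond the scatter, in no firm direction. Compound 4 is estimated at 35%, with a range from 20% to 50%, pending its measurement in this assay.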

Compound 4, a percentage reported as inhibition, at one concentration (the size of the read-out at that concentration, not a potency): 25%
Beside the measured number, compound 4's estimate is 10 percentage points above it; measured number inside the range.
By their numbers in this assay, from the lowest: compound 3; then compound 4; then compounds 1 and 2 (each within the scatter of the next).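

In this assay, for the compounds shown here, the exchange of methyl for chloro on an aromatic carbon para to a large group is not neutral, with a number 12 percentage points lower from compound 2 to compound 4 (beyond the scatter), and this is the first step in the set that isolates a single change. Compound 1 also carries a chloro group and gives 36%, whereas compound 4 gives 25%, so the presence of chloro on the ring does not by itself fix the number, and its place on the ring may matter. No measurement at hand bears on the reason for this step.

The compounds shown leave open whether a fluoro, a trifluoromethyl or an amine at this same place would give a number nearer to that of compound 2 or to that of compound 4, and a single exchange cannot show a trend across such groups. As far as these compounds go, compound 3 differs from the others in more than one place, so its number cannot be tied to any one change, and it remains open whether the exchange of methyl for chloro would have the same effect on a core carrying the carbonyl of compound 3.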